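The compounds below may be only part of what the source reports. "The series", "measured", "known", "first", "only" and "open" are said of these compounds alone.

Series notes. Compound 1 `CC(C)c1ccc(-n2nc(-c3ccc(C(F)(F)F)cc3O)nc2-c2ccccc2O)cc1` gives in a functional assay on PC-12 cells (Rattus norvegicus) for cytotoxicity, read by MTT assay, with stated times of 2 h and 24 h, tested at 1 uM (on this read-out lower numbers stand for a weaker effect and higher numbers for a stronger effect at the one concentration tested), 69.7%. Compound 2 `CC(C)(C)c1ccc(-n2nc(-c3ccc(C(F)(F)F)cc3O)nc2-c2ccccc2O)cc1` gives in this assay 67.3%, and compound 3 `Oc1cc(C(F)(F)F)ccc1-c1nc(-c2ccccc2O)n(-c2ccc(OC(F)(F)F)cc2)n1` gives in this assay 65.5%, the lowest of the three numbers, though its gaps to the other two lie within the scatter. Compound 4 `Oc1cc(C(F)(F)F)ccc1-c1nc(-c2ccccc2O)n(-c2cccc(Cl)c2)n1` differs from compound 3 by 3-chlorophenyl in place of 4-(trifluoromethoxy)phenyl on an aromatic nitrogen. Going by the values given here, the steps that bear on this place are a number 4.2 percentage points lower from compound 1 to compound 3 (within the scatter) and a number 1.8 percentage points lower from compound 2 to compound 3 (within the scatter), both exchanges of the group on the aromatic nitrogen, neither beyond the scatter. A further exchange at that place is therefore expected to give no step beyond the scatter in this assay. For compound 4 the expected value in this assay is 66%, within 56% to 76%, an expected step of a number 0.5 percentage points higher from compound 3 to compound 4 (within the scatter).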

Compound 4, a percentage reported as activity, at one concentration (the size of the read-out at that concentration, not a potency): 72.3%
For compound 4 the middle estimate is 6.3 percentage points below the measured one; measured number inside the range.
By their numbers in this assay, from the lowest: compounds 3, 2, 1 and 4 (each within the scatter of the next).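

In this assay the aromatic nitrogen also accepts 3-chlorophenyl, a ring substituted differently from the three 4-substituted phenyl groups, and all three new steps stay within the scatter (a number 6.8 percentage points higher from compound 3 to compound 4 (within the scatter)) and (a number 5 percentage points higher from compound 2 to compound 4 (within the scatter)) and (a number 2.6 percentage points higher from compound 1 to compound 4 (within the scatter)). Going from 11 heavy atoms to 7 and losing the one hydrogen-bond acceptor of 4-(trifluoromethoxy)phenyl therefore gives no step beyond the scatter. No measurement here offers an explanation for these numbers.
Still open, from the compounds shown here alone, is whether an amine or a carboxylic acid on this phenyl ring, or a plain unsubstituted phenyl, would leave the number within the scatter. Going by these compounds, whether 3-chlorophenyl and 4-chlorophenyl differ also stays open.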